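Furan in Place of Dimethoxyphenyl on a Pyridinone Nitrile

A few compounds are considered here, and "the series" means these few. Any claim that something is new, unique, unknown or untested is made for them only; others in the source may bear on it.

Of the compounds shown here, three sharing one core have been measured in a functional assay for inhibition, tested at 60 ug/mL; a lower number here means a weaker effect, a higher number a stronger effect of the compound at the concentration tested. Compound 1 `Cc1cc(O)c(C(C)C)cc1-c1cc(-c2cccs2)c(C#N)c(=O)[nH]1` gives 54.3%, compound 2 `COc1ccc(-c2cc(-c3cc(C(C)C)c(O)cc3C)[nH]c(=O)c2C#N)c(OC)c1` gives 48.5%, and compound 3 `COc1cc(OC)c(-c2cc(-c3cc(C(C)C)c(O)cc3C)[nH]c(=O)c2C#N)c(OC)c1` gives 66%. Compound 2 therefore holds the lowest of the three numbers: its gap to compound 1 is within the scatter, while its gap to compound 3 is beyond it. Two measured steps exist. The swap of the thiophen-2-yl ring for a dimethoxyphenyl ring gave a number 5.8 percentage points lower from compound 1 to compound 2 (within the scatter), and adding a methoxy group gave a number 17.5 percentage points higher from compound 2 to compound 3 (beyond the scatter).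

Compound 4 `Cc1cc(O)c(C(C)C)cc1-c1cc(-c2ccco2)c(C#N)c(=O)[nH]1` is not yet measured. It differs from compound 2 in that (furan-2-yl in place of 2,4-dimethoxyphenyl on an aromatic carbon). Within the data shown here, the step that bears on this is the one from compound 1 to compound 2, where a small five-membered heteroaryl ring stood in place of the dimethoxyphenyl ring and the effect stayed within the scatter. Compound 4 carries a furan-2-yl ring of the same kind. He expects compound 4 to land near compound 1, with a number 4.5 percentage points higher from compound 2 to compound 4 (within the scatter) and no change beyond the scatter. The estimate for compound 4 in this assay is 53%, with a range from 40% to 66%.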

Compound 4, a percentage reported as inhibition, at one concentration (the size of the read-out at that concentration, not a potency): 55.2%
Compound 4: middle estimate off by 2.2 percentage points, on the low side; the range from low to high includes it.
By their numbers in this assay, from the lowest: compounds 2, 1 and 4 (each within the scatter of the next); then compound 3.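

In this assay the furan-2-yl ring gives a number 6.7 percentage points higher from compound 2 to compound 4 (within the scatter), and in place of the thiophen-2-yl ring it gives a number 0.9 percentage points higher from compound 1 to compound 4 (within the scatter). At this carbon, opposite the ring nitrogen and ortho to the cyano group, the 2,4-dimethoxyphenyl group can thus give way to furan-2-yl, with fewer heavy atoms and a five-membered aromatic ring, without a step beyond the scatter, and the two five-membered rings cannot be told apart. Nothing available here accounts for this result. Open is whether an amine or a carboxylic acid on this carbon would move the number beyond the scatter; every group shown here is an aromatic ring. Also open, from the compounds shown here alone, is whether a methoxy group on the furan-2-yl ring would bring a step like a number 17.5 percentage points higher from compound 2 to compound 3 (beyond the scatter).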